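Ethyl Ester in Place of Acid on a Shared Core

This account rests on a few compounds, and the source may have more. Where it says the series, first, only, none or still open, it means among the compounds named here.

Compound 3 `CCOC(=O)c1cccc(NC(=O)[C@@H]2C[C@H](SC3=C(C(=O)O)N4C(=O)[C@H]([C@@H](C)O)[C@H]4[C@H]3C)CN2)c1` carries a free carboxylic acid on the shared core; in an ADME assay on a cell-free system (plasma, Rattus norvegicus) for metabolic stability, read by LC-MS, with a stated time of 60 min, at 37 degrees C, tested at 50 uM (a lower number here means that less of the compound is left, a higher number that more of the compound is left), compound 3 has "not determined" (no result reported), so no number anchors it. Compound 2 `C[C@@H](O)[C@H]1C(=O)N2C(C(=O)O)=C(S[C@@H]3CN[C@H](C(=O)Nc4cccc(C(=O)OCC(F)(F)F)c4)C3)[C@H](C)[C@H]12` is likewise reported as "not determined" (no result reported) in this assay. Within the data shown here, the only measured point is compound 1 `CCOC(=O)C1=C(S[C@@H]2CN[C@H](C(=O)Nc3cccc(C(=O)OCC)c3)C2)[C@H](C)[C@@H]2[C@@H]([C@@H](C)OC(=O)CC)C(=O)N12`, which gives 0% in this assay. Compound 4 `CCOC(=O)C1=C(S[C@@H]2CN[C@H](C(=O)Nc3cccc(C(=O)OCC)c3)C2)[C@H](C)[C@@H]2[C@@H]([C@@H](C)O)C(=O)N12` arises from compound 3 by a single change, (ethyl in place of hydrogen on an oxygen next to a carbonyl group), giving an ethoxycarbonyl where compound 3 has a carboxy. Among the measured compounds shown here, no measured step covers this change, so its size and direction cannot be read from the numbers. Compound 1 also carries an ethoxycarbonyl at the same place and is fully consumed, which is the nearest guide. Compound 4 is therefore expected to be largely consumed in this assay, estimated at 10% with a range from 0% to 40%.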

Compound 4, percent of the compound remaining: 0%
Estimate against measurement, compound 4: 10 percentage points above; the measured number falls inside the stated range.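

In this assay, hydrogen in place of propanoyl on an oxygen on a saturated carbon gives no change at the digits printed from compound 1 to compound 4 (within the scatter). The propanoyl group is therefore not needed for the complete loss seen with compound 1, since compound 4 lacks it and none of it remains either. Nothing shown here explains this loss. Compound 3 gives "not determined" (no result reported), so the step to compound 4 cannot be read. From the compounds shown here alone, whether a longer chain, such as butyl in place of ethyl on an oxygen next to a carbonyl group, would leave any compound remaining stays open.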